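Chain variation on the shared core: estimating compound 3

The compounds below may be only part of what the source reports. "The series", "measured", "known", "first", "only" and "open" are said of these compounds alone.

Going by the values given here, compound 2 `N#CSCC(=O)Nc1nncs1` gives 25.7% in a functional assay for inhibition, tested at 1 mg/mL (a higher number here means more inhibition at the concentration tested (going by the name of the read-out), a lower number less inhibition), the lowest of the two numbers measured so far, though within the scatter of compound 1 `O=C(CCl)Nc1nncs1`, which gives 27.1%. Among the compounds with values here, the one measured step, a number 1.4 percentage points lower from compound 1 to compound 2 (within the scatter), touches the same place on the chain and stayed within the scatter. Compound 3 `N#CCC(=O)Nc1nncs1` carries the change (cyano in place of cyanosulfanyl on a saturated chain carbon bound to a carbonyl carbon). Since the earlier change at this place moved nothing beyond the scatter, no step beyond the scatter is expected in this assay. Compound 3 is therefore estimated at 25%, with a range of 14% to 36%. The expected step is a number 0.7 percentage points lower from compound 2 to compound 3 (within the scatter).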

Compound 3, a percentage reported as inhibition, at one concentration (the size of the read-out at that concentration, not a potency): 70.9%
Beside the measured number, compound 3's estimate is 45.9 percentage points below it; the measured number lies above the stated range.
By their numbers in this assay, from the lowest: compounds 2 and 1 (each within the scatter of the next); then compound 3.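

The place on a saturated chain carbon bound to a carbonyl carbon can move the read-out in this assay after all: cyano in place of cyanosulfanyl gives a number 45.2 percentage points higher from compound 2 to compound 3 (beyond the scatter) and cyano in place of chloro gives a number 43.8 percentage points higher from compound 1 to compound 3 (beyond the scatter) on the same carbon. Compound 1 and compound 2 stay within the scatter of each other, so only cyano stands apart among the three groups. No measurement here bears on the reason for these steps.

Open, on these data alone, is whether the rise is particular to cyano or would also appear with an amine or a carboxylic acid at this place. Also open, as far as these compounds go, is whether a longer chain carrying the nitrile would keep it.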